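A new aromatic group on compound 2

The source may report more compounds than this note shows. Statements on the series, on what has been measured and on what is new or still open speak of the compounds shown alone.

Of the compounds shown here, two sharing one core have so far been tested in a functional assay on HL-60 cells (Homo sapiens) for cytotoxicity, read by CellTiter-Blue, with a stated time of 48 h; a lower number here means a stronger inhibitor, a higher number a weaker inhibitor. Compound 1 (`CCOC(=O)CC1C(C(=O)OCC)=C(N)Oc2ccc(-c3ccco3)cc21`) reads > 80000 nM, which is a limit of the assay and not a number. Going by the values given here, compound 2 (`CCOC(=O)CC1C(C(=O)OCC)=C(N)Oc2ccc(-c3ccnc(OC)c3)cc21`) gives 10200 nM, the only true number so far. Among the compounds with values here, its sole comparison is therefore with a limit. Within the data shown here, one measured step bears on the next change: placing 2-methoxypyridin-4-yl where furan-2-yl stood on an aromatic carbon gave an at least 7.8-fold lower number from compound 1 to compound 2 (0.89 log units; beyond the scatter). Compound 3 (`CCOC(=O)CC1C(C(=O)OCC)=C(N)Oc2ccc(-c3cccc(C(N)=O)c3)cc21`) changes that same carbon again: 3-carbamoylphenyl in place of 2-methoxypyridin-4-yl on an aromatic carbon. The group at this carbon can clearly matter, but a single step cannot show how a 3-carbamoylphenyl group will shift the number. With only an at least 7.8-fold lower number from compound 1 to compound 2 (0.89 log units; beyond the scatter) as a guide, no large move in either direction is expected, and the range must stay wide. The expected change is a 1.5-fold higher number from compound 2 to compound 3 (0.17 log units; within the scatter), which stays within the scatter and leans slightly towards a weaker number. For compound 3 the estimate is 15000 nM, with an expected range from 4000 nM to 60000 nM.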

Compound 3, half-maximal inhibitory concentration: 5400 nM
Estimate against measurement, compound 3: 2.8-fold (0.44 log units) above; the range from low to high includes it.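

In this assay, 3-carbamoylphenyl in place of 2-methoxypyridin-4-yl gives a 1.9-fold lower number from compound 2 to compound 3 (0.28 log units; within the scatter) and so leaves the two groups indistinguishable here, although one has a ring of carbon only and a hydrogen-bond donor that the other lacks. Replacing furan-2-yl with 3-carbamoylphenyl gives an at least 14-fold lower number from compound 1 to compound 3 (1.17 log units; beyond the scatter) and adds a second, differently substituted six-membered aromatic ring that stands clear of compound 1, so the earlier change at this carbon does not depend on the ring nitrogen or the methoxy group of compound 2. The true size of this step stays unknown, as compound 1 sits at a limit of the assay and not at a number: the limit of > 80000 nM in this assay, at which 1 of the 3 values shown sits.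

The compounds shown leave open whether the carbamoyl group contributes anything of its own, which a plain phenyl ring, a nitrile or a carboxylic acid at the same place on the ring would help to settle. They also leave open whether a saturated ring or a short alkyl chain at this carbon would keep the number of compound 2 and compound 3 or lose it as compound 1 does.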